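The source may hold more compounds than are shown below. What is called first, only, known or untested is meant among the compounds shown, and "the series" means these compounds.

Measured compounds:

Compound 1 `Nc1scc(CN2CCN(c3cc(Cl)cc(Cl)c3)CC2)c1C(=O)c1ccc(Cl)cc1` gives 1% in an assay on CHO cells for displacement of a labelled ligand from adenosine receptor A1 (Homo sapiens), read by scintillation counting, with a stated time of 120 min, tested at 10 uM; on this read-out lower numbers stand for less inhibition and higher numbers for more inhibition at the one concentration tested (going by the name of the read-out).
Compound 2 `Nc1scc(CN2CCN(c3ccc([N+](=O)[O-])cc3)CC2)c1C(=O)c1ccc(Cl)cc1` gives 1% in this assay.
Compound 3 `Nc1scc(CN2CCN(c3cccc4ccccc34)CC2)c1C(=O)c1ccc(Cl)cc1` gives 1% in this assay.

All three compounds share one core and differ only in the aromatic group carried on an amine nitrogen in a ring. On the numbers shown, compound 2 stands level with compounds 1 and 3: its value sits at the same digits as that of compound 1 and of compound 3, so none of the three can be called stronger or weaker than another. The steps among them say the same. There is no change at the digits printed from compound 1 to compound 2 (within the scatter), no change at the digits printed from compound 1 to compound 3 (within the scatter) and no change at the digits printed from compound 2 to compound 3 (within the scatter), so swapping one aromatic group for another on this nitrogen has left the read-out where it was in every case tried.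

Compound 4 `Nc1scc(CN2CCN(c3ccc(F)cc3F)CC2)c1C(=O)c1ccc(Cl)cc1` is not yet measured. Compared with compound 2 the change is 2,4-difluorophenyl in place of 4-nitrophenyl on an amine nitrogen in a ring. All three measured steps bear on it, since each also exchanges the aromatic group on the same ring nitrogen, and each was within the scatter. The expected step is therefore no change at the digits printed from compound 2 to compound 4 (within the scatter), with no movement beyond the scatter in either direction. Compound 4 is estimated to give 1% in this assay, within a range from 0% to 10%.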

Compound 4, a percentage reported as inhibition, at one concentration (the size of the read-out at that concentration, not a potency): 1%
Estimate against measurement, compound 4: no gap at the digits printed; low and high end bracket the measured number.
By their numbers in this assay, from the lowest: compounds 1, 2, 3 and 4 (each within the scatter of the next).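

In this assay, the 2,4-difluorophenyl group behaves like the aromatic groups before it, with no change at the digits printed from compound 2 to compound 4 (within the scatter), no change at the digits printed from compound 3 to compound 4 (within the scatter) and no change at the digits printed from compound 1 to compound 4 (within the scatter). This adds a fluorine-bearing ring to the set on this ring nitrogen, and the exchange of 4-nitrophenyl, which has hydrogen-bond acceptors and a double bond outside the aromatic ring, for 2,4-difluorophenyl, which has neither, leaves the read-out where it was. No accompanying measurement explains why the read-out stays flat across these four compounds.

Going by these compounds, all the groups on this nitrogen so far are aromatic rings attached directly, so it remains open whether a benzyl group, a cyclohexyl group, an acetyl group or a phenyl ring bearing a carboxylic acid or an amine would move the number at the one concentration tested. With all four compounds level, the read-out also gives no sign of whether this nitrogen matters more or less than other parts of the shared core, and a change elsewhere on that core, such as replacing its free amine with an amide, could be tried against it.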